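A few compounds are considered here, and "the series" means these few. Any claim that something is new, unique, unknown or untested is made for them only; others in the source may bear on it.

Of the compounds shown here, three have so far been measured in an ADME assay on microsomes from liver (Rattus norvegicus) for metabolic stability, tested at 2.5 uM; a lower number here means slower removal, a higher number faster removal of the compound. Compound 1 `O=S(=O)(c1cc(Cl)cc(Cl)c1)c1cnc2cc(F)ccc2c1-c1ccc(Cl)cc1` gives 0.77 mL/min in this assay, and compound 2 `O=S(=O)(c1cc(Cl)cc(Cl)c1)c1cnc2cc(F)ccc2c1-c1ccc(F)cc1` gives 1.15 mL/min. The change between them, (fluoro in place of chloro on an aromatic carbon), made a 1.5-fold higher number from compound 1 to compound 2 (0.17 log units; within the scatter). Compound 3 `O=S(=O)(c1ccc(F)cc1)c1cnc2cc(Cl)ccc2c1-c1ccc(Cl)cc1` gives 0.01 mL/min in this assay; the difference between its core and the core of compound 1 is not broken down here, and the values show compound 3 far lower than both compound 1 and compound 2.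

Compound 4 `O=S(=O)(c1ccc(F)cc1)c1cnc2cc(F)ccc2c1-c1ccc(Cl)cc1` has not yet been measured. It differs from compound 3 by fluoro in place of chloro on an aromatic carbon. Among the compounds with values here, this is the same kind of change as the one from compound 1 to compound 2, but not the same: there the exchanged atom sat on a six-membered aromatic ring of carbon only, para to a large group, whereas here it sits on a ring that is part of a fused or bridged system of two rings, meta to a fused ring and para to a fused ring. Because the earlier step of a 1.5-fold higher number from compound 1 to compound 2 (0.17 log units; within the scatter) was small, the step expected for compound 4 is also small, a 1.5-fold higher number from compound 3 to compound 4 (0.18 log units; within the scatter), although the different surroundings make this only a loose guide. Compound 4 is therefore estimated to give 0.015 mL/min, most likely between 0.005 mL/min and 0.05 mL/min.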

Compound 4, intrinsic clearance in a liver preparation (reported as CLH), per the amount of preparation that the assay uses: 0.89 mL/min
Compound 4: middle estimate off by 59-fold (1.77 log units), on the low side; measured number outside the range, above it.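

In this assay, within the data shown here, fluoro in place of chloro on an aromatic carbon did not carry the same size of step from one core to the other: the same change on two cores in this assay, a 1.5-fold higher number (0.17 log units; within the scatter) from compound 1 to compound 2 and an 89-fold higher number (1.95 log units; beyond the scatter) from compound 3 to compound 4, 60-fold (1.78 log units) apart, beyond the scatter of two such steps The other new step, 4-fluorophenyl in place of 3,5-dichlorophenyl on a sulfonyl sulfur, gives a 1.2-fold higher number from compound 1 to compound 4 (0.06 log units; within the scatter), while the large step, an 89-fold higher number from compound 3 to compound 4 (1.95 log units; beyond the scatter), rests on the single very low value of compound 3, 0.01 mL/min. This shows that the size of the halogen exchange cannot simply be transferred within this series, but it does not show why the two steps differ, as the exchanged atom sits on a different ring in each pair and the sulfonyl substituents differ too.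

On these data alone, it remains open whether the low number of compound 3 is specific to chloro on the ring that is part of the fused system. A methoxy group or a nitrile in that place could show whether other groups give numbers close to compound 3 or close to compound 4.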